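The source may report more compounds than this note shows. Statements on the series, on what has been measured and on what is new or still open speak of the compounds shown alone.

Three compounds have been measured in a functional assay on MCF7 cells (Homo sapiens) for antiproliferative activity, read by MTT assay, with a stated time of 48 h; a higher number here means a weaker inhibitor, a lower number a stronger inhibitor:

Compound 1 `N#CC1=C(N)Oc2c(c3nc4ccccc4nc3c3ccccc23)C12C(=O)N(Cc1cnnn1-c1ccc(Cl)cc1)c1ccccc12` — a limit only: > 50000 nM
Compound 2 `CCOc1ccc(-n2nncc2CN2C(=O)C3(C(C#N)=C(N)Oc4c3c3nc5ccccc5nc3c3ccccc43)c3ccccc32)cc1` — a limit only: > 50000 nM
Compound 3 `N#CC1=C(N)Oc2c(c3nc4ccccc4nc3c3ccccc23)C12C(=O)N(Cc1cnnn1-c1ccc([N+](=O)[O-])cc1)c1ccccc12` — a limit only: > 50000 nM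

Compound 3 therefore stands nowhere in particular on a scale: its result is a limit of this assay, not a number. The same holds for every value in the set, since all three sit at the limit of > 50000 nM in this assay, at which 3 of the 3 values shown sit. The compounds differ from one another only in the group carried on the phenyl ring attached to the triazole, yet none of those changes can be read: a step that the two limits leave unreadable from compound 1 to compound 2, a step that the two limits leave unreadable from compound 1 to compound 3 and a step that the two limits leave unreadable from compound 2 to compound 3 all fall between two limits and have no measurable size.

Compound 4 `N#CC1=C(N)Oc2c(c3nc4ccccc4nc3c3ccccc23)C12C(=O)N(Cc1cnnn1-c1ccc(S(N)(=O)=O)cc1)c1ccccc12` continues the series with one further exchange at that position, (sulfamoyl in place of nitro on an aromatic carbon). Among the compounds with values here, no measured step bears on it in a readable way, so no direction can be taken from the data; the only evidence is that every neighbour sits at the limit. Compound 4 is therefore expected, most likely, to give another limit rather than a number in this assay. Compound 4 is estimated at 60000 nM, with a range from 15000 nM to 200000 nM. That corresponds to an expected step that the limit leaves unreadable from compound 3 to compound 4, no change beyond the scatter.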

Compound 4, half-maximal inhibitory concentration: > 50000 nM
Compound 4: no number, only a limit; the forecaster's own chance of this, stated with the estimate: 85%; the middle value lies beyond the limit too.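

Within the data shown here, compound 4 also gives only a limit, so no step among compound 1, compound 2, compound 3 and compound 4 can be read, and all four share one result: the limit of > 50000 nM in this assay, at which 4 of the 4 values shown sit. As far as these compounds go, whether any group on this phenyl ring can bring a measurable value in this assay stays open.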